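The source may hold more compounds than are shown below. What is called first, only, known or untested is meant among the compounds shown, and "the series" means these compounds.

Compound 2 `Cc1ccc(-c2cn(C[C@H]3c4c(ccc(O)c4C)[C@@H]4CC[C@@]5(C)C[C@]43CC5=O)nn2)cc1` is known in a functional assay on HL-60 cells (Homo sapiens) for cytotoxicity, read by MTT assay, with a stated time of 4 days (on this read-out higher numbers stand for weaker inhibition and lower numbers for stronger inhibition), only as a limit: compound 2 gives > 20000 nM. For the measured compounds named here, its single measured neighbour, compound 1 `Cc1c(O)ccc2c1[C@H](Cn1cc(-c3ccc(Cl)cc3)nn1)[C@@]13CC(=O)[C@@](C)(CC[C@@H]21)C3`, also stands at a limit, and in this assay compound 1 gives > 20000 nM. The step that the two limits leave unreadable from compound 1 to compound 2 cannot be read since both values sit at the limit of > 20000 nM in this assay, at which 2 of the 2 values shown sit. Compound 3 `COc1ccc(-c2cn(C[C@H]3c4c(ccc(O)c4C)[C@@H]4CC[C@@]5(C)C[C@]43CC5=O)nn2)cc1` carries methoxy in place of methyl on an aromatic carbon. Going by the values given here, no measured step bears on this change, and the reference value is a limit, so the expected step of a number no higher from compound 2 to compound 3 (the limit leaves the size open) is none readable beyond the scatter. Compound 3 is estimated at 20000 nM, between 8000 nM and 60000 nM, most probably again reported as a limit.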

Compound 3, half-maximal inhibitory concentration: > 20000 nM
Compound 3 was reported as a limit (the forecaster's own chance of this, stated with the estimate: 85%); the middle value lies on the limit itself.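

For the compounds shown here, no step between compound 1, compound 2 and compound 3 can be read, since all three values are limits: the limit of > 20000 nM in this assay, at which 3 of the 3 values shown sit. The compounds shown leave open whether chloro, methyl and methoxy on this aromatic carbon differ at all in this assay.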